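The source may hold more compounds than are shown below. What is called first, only, known or untested is meant among the compounds shown, and "the series" means these compounds.

In an ADME assay on C8166 cells (Homo sapiens) for cytotoxicity, read by MTT assay (a higher number here means that more compound is tolerated, a lower number that less compound is tolerated), compound 2 `CCC(C)n1cc(C(=O)O)c(=O)c2c(O)c(Cc3cccc(Cl)c3F)ccc21` gives 30700 nM and compound 1 `CCCCCn1cc(C(=O)O)c(=O)c2c(O)c(Cc3cccc(Cl)c3F)ccc21` gives 39900 nM. These two stand together at the upper end of the three numbers, with a 1.3-fold lower number from compound 1 to compound 2 (0.11 log units; within the scatter). Compound 3 `O=C(O)c1cn(C2CCCC2)c2ccc(Cc3cccc(Cl)c3F)c(O)c2c1=O` gives 12400 nM, and the gap to it is a 2.5-fold lower number from compound 2 to compound 3 (0.39 log units; beyond the scatter). Compound 4 `O=C(O)c1cn(C2CCCCC2)c2ccc(Cc3cccc(Cl)c3F)c(O)c2c1=O` carries cyclohexyl in place of sec-butyl on an aromatic nitrogen. The nearest measured change, cyclopentyl in place of sec-butyl, is a 2.5-fold lower number from compound 2 to compound 3 (0.39 log units; beyond the scatter), and a 3.2-fold lower number from compound 1 to compound 3 (0.51 log units; beyond the scatter) runs the same way. For the measured compounds named here, no cyclohexyl compound has been measured, so a similar modest drop in this assay is only an expectation. The expected step is a 2.2-fold lower number from compound 2 to compound 4 (0.34 log units; beyond the scatter). Compound 4 is estimated at 14000 nM, within an expected range of 6000 nM to 32000 nM.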

Compound 4, half-maximal cytotoxic concentration: 17400 nM
Estimate against measurement, compound 4: 1.2-fold (0.09 log units) below; the measured number falls inside the stated range.
By their numbers in this assay, from the lowest: compounds 3, 4, 2 and 1 (each within the scatter of the next, the first and the last beyond it).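

In this assay, cyclohexyl on the aromatic nitrogen does not separate from the groups closest to it: a 1.8-fold lower number from compound 2 to compound 4 (0.25 log units; within the scatter) and a 1.4-fold higher number from compound 3 to compound 4 (0.15 log units; within the scatter) leave compound 4 within the scatter of both sec-butyl and cyclopentyl. For the compounds shown here, only pentyl stands apart, with a 2.3-fold lower number from compound 1 to compound 4 (0.36 log units; beyond the scatter) as the one new step beyond the scatter, so compound 4 joins compound 3 in lying clear of compound 1. No measurement offered here explains these differences. On these data alone, whether an amine or a hydroxyl on the cyclohexyl ring, or a chain longer than pentyl, would shift this number remains open.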